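Amino substitution on two related cores: cytotoxicity in U-937 cells

This account rests on a few compounds, and the source may have more. Where it says the series, first, only, none or still open, it means among the compounds named here.

Compound 1 `CCn1cc(-c2nc3ccccc3[nH]2)c(=O)c2cc(F)c(N3CCNCC3)cc21` and compound 2 `CCn1cc(-c2nc3ccccc3[nH]2)c(=O)c2cc(F)c(N3CCNCC3)nc21` share most of their structure; the difference between the two cores is not broken down here. In a functional assay on U-937 cells (Homo sapiens) for cytotoxicity, read by sulforhodamine B assay, with a stated time of 48 h (a lower number here means a stronger inhibitor, a higher number a weaker inhibitor), compound 1 gives only a limit, > 10000 nM. Compound 2 likewise gives only a limit in this assay, > 10000 nM. Compound 3 `CCn1cc(-c2nc3ccc(N)cc3[nH]2)c(=O)c2cc(F)c(N3CCNCC3)cc21` arises from compound 1 by amino in place of hydrogen on an aromatic carbon, and compound 3 too reaches only a limit in this assay, > 10000 nM. The step that the two limits leave unreadable from compound 1 to compound 3 thus cannot be sized, since (the limit of > 10000 nM in this assay, at which 3 of the 3 values shown sit). Compound 4 `CCn1cc(-c2nc3ccc(N)cc3[nH]2)c(=O)c2cc(F)c(N3CCNCC3)nc21` arises from compound 2 by the same change, (amino in place of hydrogen on an aromatic carbon). Because the limit of > 10000 nM in this assay, at which 3 of the 3 values shown sit, the step to compound 4 is expected to stay unreadable, estimated as a step that the limit leaves unreadable from compound 2 to compound 4. Compound 4 is therefore expected near 20000 nM, between 8000 nM and 60000 nM, most probably again as a limit.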

Compound 4, half-maximal inhibitory concentration: > 10000 nM
Compound 4: no number, only a limit; the forecaster's own chance of this, stated with the estimate: 90%; the middle value is on the limit's open side.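

No size can be read for the step between compound 2 and compound 4, since both give only limits: the limit of > 10000 nM in this assay, at which 4 of the 4 values shown sit. From the compounds shown here alone, how strong compound 1, compound 2, compound 3 and compound 4 actually are, and whether amino in place of hydrogen changes that on either core, stays open.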